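The compounds below may be only part of what the source reports. "The series", "measured", "known", "first", "only" and "open" are said of these compounds alone.

Measured compounds:
compound 1 `CC(O)c1cccc(C(=O)N[C@@H](C)Cn2ccc(-c3ccc(C#N)c(Cl)c3)n2)c1`, 2280 nM
compound 2 `CC(=O)c1ccc(C(=O)N[C@@H](C)Cn2ccc(-c3ccc(C#N)c(Cl)c3)n2)cc1`, 3600 nM
compound 3 `C[C@@H](Cn1ccc(-c2ccc(C#N)c(Cl)c2)n1)NC(=O)C1CC(=O)C1`, 3040 nM

In a functional assay on LNCaP cells (Homo sapiens) for antiproliferative activity, read by CCK-8 assay, with a stated time of 6 days (on this read-out higher numbers stand for weaker inhibition and lower numbers for stronger inhibition), compound 3 gives 3040 nM. Its nearest neighbour is compound 2, a 1.2-fold lower number from compound 2 to compound 3 (0.07 log units; within the scatter); compound 1 is a little further off, a 1.3-fold higher number from compound 1 to compound 3 (0.12 log units; within the scatter). The third measured step, a 1.6-fold higher number from compound 1 to compound 2 (0.20 log units; within the scatter), is of the same small size, so the three amide variants are indistinguishable on this read-out.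

Compound 4 `C[C@@H](Cn1ccc(-c2ccc(C#N)c(Cl)c2)n1)Nc1ccccn1` takes a different step: pyridin-2-yl in place of (3-oxocyclobutyl)carbonyl on an amine nitrogen. Among the compounds with values here, none of the measured steps touches this position; all three exchange the group on the carbonyl carbon and leave the amide itself in place. Within the data shown here, no measured step therefore bears on the change, and the flat run among compounds 1, 2 and 3 gives no direction. The step is expected to be a 1.3-fold higher number from compound 3 to compound 4 (0.12 log units; within the scatter), with wide uncertainty. Compound 4 is estimated at 4000 nM, in the range 1000 nM to 16000 nM.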

Compound 4, half-maximal inhibitory concentration: 1110 nM
Compound 4: middle estimate off by 3.6-fold (0.56 log units), on the high side; low and high end bracket the measured number.
By their numbers in this assay, from the lowest: compound 4; then compounds 1, 3 and 2 (each within the scatter of the next).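

In this assay, the amine nitrogen proves to be a position where the read-out moves: with pyridin-2-yl in place of (3-oxocyclobutyl)carbonyl, there is a 2.7-fold lower number from compound 3 to compound 4 (0.44 log units; beyond the scatter), whereas the changes on the carbonyl carbon all stayed within the scatter. The step also shows that the amide carbonyl can be absent without loss of activity on this read-out. No available evidence accounts for this step.

The compounds shown leave open whether the step depends on the ring nitrogen of pyridin-2-yl or on the loss of the carbonyl. A phenyl or pyrimidin-2-yl group on the same amine nitrogen would help separate these.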